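A few compounds are considered here, and "the series" means these few. Any claim that something is new, unique, unknown or untested is made for them only; others in the source may bear on it.

Measured compounds in a functional assay on LAC cells (Homo sapiens) for cytotoxicity, read by MTT assay, with a stated time of 72 h; on this read-out higher numbers stand for an effect only at larger amounts of compound and lower numbers for an effect already at smaller amounts:
Compound 1, `CCS[C@@H]1[C@H](SCC)[C@@H](Cn2cc(-c3ccc(F)cc3)nn2)O[C@H]1n1ccc(=O)[nH]c1=O`, gives 72400 nM.
Compound 2, `CCOC(=O)c1cn(C[C@H]2O[C@@H](n3ccc(=O)[nH]c3=O)[C@H](SCC)[C@@H]2SCC)nn1`, gives >= 100000 nM, which is a limit of the assay rather than a number.
Compound 3, `CCS[C@@H]1[C@H](SCC)[C@@H](Cn2cc(-c3ccc(F)cc3)nn2)O[C@H]1n1cc(C)c(=O)[nH]c1=O`, gives >= 100000 nM, again a limit of the assay and not a number.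

For the measured compounds named here, compound 3 therefore stands at the ceiling of what this assay reports, as does compound 2, while only compound 1 has a measured number; the gap an at least 1.3-fold higher number from compound 1 to compound 3 (0.14 log units; that floor lies within the scatter) is the one step that reaches compound 3.

Compound 4, `CCS[C@@H]1[C@H](SCC)[C@@H](Cn2cc(-c3cccs3)nn2)O[C@H]1n1cc(C)c(=O)[nH]c1=O`, keeps the methyl on the core of compound 3 and changes the group on the triazole: thiophen-2-yl in place of 4-fluorophenyl on an aromatic carbon. Going by the values given here, no measured pair shows this particular swap. The closest evidence is an at least 1.3-fold higher number from compound 1 to compound 2 (0.14 log units; that floor lies within the scatter), where replacing the 4-fluorophenyl by ethoxycarbonyl moved the value to the limit, and an at least 1.3-fold higher number from compound 1 to compound 3 (0.14 log units; that floor lies within the scatter), where adding the methyl did the same; both steps end at the limit of >= 100000 nM in this assay, at which 2 of the 3 values shown sit. Since compound 3 already sits there, the step to compound 4 is expected to show no change beyond the scatter, a number no higher from compound 3 to compound 4 (the limit leaves the size open), and a further limit is the most probable outcome.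

Compound 4 is accordingly estimated at 100000 nM, in a range from 50000 nM to 300000 nM.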

Compound 4, half-maximal effective concentration: >= 100000 nM
Compound 4: a limit, no number; the forecaster's own chance of this, stated with the estimate: 70%; the middle value lies on the limit itself.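

In this assay compound 4 gives >= 100000 nM, which is a limit of the assay and not a number. Compound 3 also stands at a limit, so no step can be read between compound 3 and compound 4. The compounds shown leave open whether thiophen-2-yl in place of 4-fluorophenyl changes the value at all, and most of them give no number: the limit of >= 100000 nM in this assay, at which 3 of the 4 values shown sit.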